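Imidazole series: branched alkyl replacing the aryl on the chain carbon

This account rests on a few compounds, and the source may have more. Where it says the series, first, only, none or still open, it means among the compounds named here.

Of the compounds shown here, three sharing one core have been measured in an in vitro functional assay on cells for agonist activity at Bombesin receptor subtype-3 (Mus musculus), read by luminescence and calcium flux; a lower number here means that less compound is needed, a higher number that more compound is needed for the effect. Compound 1 `COc1ccc(Cc2cnc(CCc3ccc(-c4ccccc4C(=O)O)cc3)[nH]2)cc1` gives 513 nM and stands second highest of the three numbers, close to compound 3 and well apart from compound 2. Compound 2 `Cc1cccc(Cc2cnc(CCc3ccc(-c4ccccc4C(=O)O)cc3)[nH]2)c1` gives 75 nM, compound 3 `O=C(O)c1ccccc1-c1ccc(CCc2ncc(-c3ccccc3)[nH]2)cc1` gives 872 nM.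

The step from compound 1 to compound 4 `CCC(C)(CC)Cc1cnc(CCc2ccc(-c3ccccc3C(=O)O)cc2)[nH]1` exchanges the group on the saturated chain carbon bound to an aromatic carbon: 1-ethyl-1-methylpropyl in place of 4-methoxyphenyl on a saturated chain carbon bound to an aromatic carbon. Going by the values given here, the nearest precedent is a 6.8-fold lower number from compound 1 to compound 2 (0.84 log units; beyond the scatter), which kept the ring and changed only its substituent. The two steps that remove the chain carbon, a 1.7-fold higher number from compound 1 to compound 3 (0.23 log units; within the scatter) and a 12-fold higher number from compound 2 to compound 3 (1.07 log units; beyond the scatter), show that what sits on that carbon matters, and that losing it from compound 2 costs more than losing it from compound 1. Among the compounds with values here, no measured step replaces the ring by an open chain, so the direction for compound 4 is not pinned down; the group on this carbon has, however, moved this assay by a modest amount when varied.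

Compound 4 is therefore expected to land not far from compound 1, with a lean toward a lower number, i.e. a 1.7-fold lower number from compound 1 to compound 4 (0.23 log units; within the scatter) as the estimated step. The estimate for compound 4 in this assay is 300 nM, with a range from 60 nM to 1500 nM.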

Compound 4, half-maximal effective concentration: 30 nM
Estimate against measurement, compound 4: 10-fold (1.00 log units) above, and the stated range ends above it.
By their numbers in this assay, from the lowest: compound 4; then compound 2; then compounds 1 and 3 (each within the scatter of the next).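

Working notes on the chain carbon: in this assay the replacement of 4-methoxyphenyl by 1-ethyl-1-methylpropyl gives a 17-fold lower number from compound 1 to compound 4 (1.23 log units; beyond the scatter) and shows that an aromatic ring on this saturated chain carbon is not needed, since the entering group has no ring and no hydrogen-bond acceptor. The open branched group also improves on the best ring-bearing compound, with a 2.5-fold lower number from compound 2 to compound 4 (0.40 log units; beyond the scatter) as a modest step beyond the scatter, which places compound 4 lowest of the four and shows that varying the ring substituent had not reached the floor at this position. Read as 2-ethyl-2-methylbutyl in place of phenyl on an aromatic carbon, the change gives a 29-fold lower number from compound 3 to compound 4 (1.46 log units; beyond the scatter) and is the largest step in the set, so this position spans more of this assay than the earlier compounds indicated.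

Still open, going by these compounds, is how the number responds to a cyclohexyl ring or a straight hexyl chain in place of 1-ethyl-1-methylpropyl on this carbon, which would separate the effect of branching from that of losing the aromatic ring. Nothing available here accounts for the gain seen with compound 4.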